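The compounds below may be only part of what the source reports. "The series", "measured", "known", "first", "only" and "open" are said of these compounds alone.

Compound 2 `CNC(=O)c1cc(Oc2ccc3nc(Nc4ccc(F)cc4)ncc3c2)ccn1` has been measured in a physicochemical assay for solubility, at pH 7; a lower number here means a less soluble compound, a higher number a more soluble compound. In this assay compound 2 gives < 1000 nM, which is a limit of the assay rather than a number. Within the data shown here, its one measured neighbour, compound 1 `CNC(=O)c1cc(Oc2ccc3nc(Nc4cccc(C(C)C)c4)ncc3c2)ccn1`, gives in this assay < 1000 nM, again a limit. The step that the two limits leave unreadable from compound 1 to compound 2 shows no size, as the limit of < 1000 nM in this assay, at which 2 of the 2 values shown sit. Compound 3 `CNC(=O)c1cc(Oc2ccc3nc(Nc4ccc(-c5cccnc5)cc4)ncc3c2)ccn1` has not been measured; it differs from compound 2 as pyridin-3-yl in place of fluoro on an aromatic carbon. Among the measured compounds shown here, no measured step bears on this change, and the two limits offer no size to expect. Compound 3 is estimated at 500 nM, with a range from 80 nM to 3000 nM. The expected step is a step that the limit leaves unreadable from compound 2 to compound 3.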

Compound 3, solubility: < 1000 nM
Compound 3: a limit, no number; the forecaster's own chance of this, stated with the estimate: 70%; the middle value lies beyond the limit too.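

No step can be read between compound 2 and compound 3 in this assay, because both values are limits rather than numbers: the limit of < 1000 nM in this assay, at which 3 of the 3 values shown sit.

Compound 1, compound 2 and compound 3 leave open how their solubilities actually compare, and whether pyridin-3-yl in place of fluoro changes anything.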